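This account rests on a few compounds, and the source may have more. Where it says the series, first, only, none or still open, it means among the compounds named here.

Three compounds of this series have numbers in a functional assay on PC-12 cells (Rattus norvegicus) for cytotoxicity, read by MTT assay, with stated times of 2 h and 24 h, tested at 10 uM; a lower number here means a weaker effect, a higher number a stronger effect of the compound at the concentration tested. Compound 1 `CC(C)c1ccc(-n2nc(-c3ccc(C(F)(F)F)cc3O)nc2-c2ccccc2O)cc1` gives 108%. Compound 2 `Oc1cc(C(F)(F)F)ccc1-c1nc(-c2ccccc2O)n(-c2ccc(Cl)cc2)n1` gives 96.1%, and compound 3 `Oc1cc(C(F)(F)F)ccc1-c1nc(-c2ccccc2O)n(-c2ccc(Br)cc2)n1` gives 100%. Compound 3 stands second highest of the three: its nearest neighbour is compound 2, with the step of a number 3.9 percentage points higher from compound 2 to compound 3 (within the scatter) within the scatter, and its furthest neighbour is compound 1, with the step of a number 8 percentage points lower from compound 1 to compound 3 (within the scatter) also within the scatter. Going by the values given here, the only step beyond the scatter among the measured compounds is a number 11.9 percentage points lower from compound 1 to compound 2 (beyond the scatter), and that one is modest.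

Compound 4 `COc1ccc(-n2nc(-c3ccc(C(F)(F)F)cc3O)nc2-c2ccccc2O)cc1` is the next member awaiting measurement. It differs from compound 3 in one place: methoxy in place of bromo on an aromatic carbon. Among the compounds with values here, the measured steps that bear on this change are those exchanging the group at the same aromatic carbon, namely a number 8 percentage points lower from compound 1 to compound 3 (within the scatter), a number 11.9 percentage points lower from compound 1 to compound 2 (beyond the scatter) and a number 3.9 percentage points higher from compound 2 to compound 3 (within the scatter); all three groups that have occupied this position gave numbers close together, and only one exchange exceeded the scatter. Methoxy itself has not been tested at this carbon, so the expectation rests on the small spread seen so far. Compound 4 is expected to give 100%, within a range of 88% to 112%. The estimated step of no change at the digits printed from compound 3 to compound 4 (within the scatter) is expected to stay within the scatter.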

Compound 4, a percentage reported as activity, at one concentration (the size of the read-out at that concentration, not a potency): 98.9%
Beside the measured number, compound 4's estimate is 1.1 percentage points above it; the range from low to high includes it.
By their numbers in this assay, from the lowest: compounds 2, 4, 3 and 1 (each within the scatter of the next, the first and the last beyond it).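

In this assay, replacing bromo, which has no hydrogen-bond acceptor, with methoxy, which has one, leaves the 4-substituted phenyl series within the scatter (a number 1.1 percentage points lower from compound 3 to compound 4 (within the scatter)), so this added oxygen has no readable effect on the number at this aromatic carbon. Methoxy also stays within the scatter of the chloro and isopropyl compounds (a number 2.8 percentage points higher from compound 2 to compound 4 (within the scatter); a number 9.1 percentage points lower from compound 1 to compound 4 (within the scatter)), so compound 4 does not side clearly with either end of the only step beyond the scatter (a number 11.9 percentage points lower from compound 1 to compound 2 (beyond the scatter)), and the four compounds form a narrow, overlapping set rather than two separate groups. Nothing available explains why these four groups give such similar numbers.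

The compounds shown leave open whether this position stays as tolerant with an amine, a carboxylic acid or a longer chain such as n-hexyl in place of these small groups. They also leave open what changes elsewhere would do, since the two hydroxyl groups and the trifluoromethyl group are the same in all four compounds, and a single tested concentration gives no view of potency.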